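This account rests on a few compounds, and the source may have more. Where it says the series, first, only, none or still open, it means among the compounds named here.

Compound 1, `Fc1ccc(-c2cn3ccnc3c(-c3ccc4ncn(C5CCCCC5)c4c3)n2)cc1`: 9.54%
Compound 2, `Brc1ccc(-c2cn3ccnc3c(-c3ccc4ncn(C5CCCCC5)c4c3)n2)cc1`: 13.2%
Compound 3, `COc1ccccc1-c1cn2ccnc2c(-c2ccc3ncn(C4CCCCC4)c3c2)n1`: 8.78%

In a functional assay on OVCAR-8 cells (Homo sapiens) for inhibition, read by sulforhodamine B assay, with a stated time of 48 h, tested at 10 uM (a lower number here means less inhibition, a higher number more inhibition at the concentration tested (going by the name of the read-out)), compound 3 gives the lowest of the three numbers, yet it stands apart from neither neighbour: the step of a number 0.8 percentage points lower from compound 1 to compound 3 (within the scatter) and the step of a number 4.4 percentage points lower from compound 2 to compound 3 (within the scatter) both fall within the scatter of this assay. The three compounds share one core and differ only in the aryl group carried on it, and all their steps in this assay are small.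

Compound 4, `FC(F)(F)c1cccc(-c2cn3ccnc3c(-c3ccc4ncn(C5CCCCC5)c4c3)n2)c1`, continues that series. Its change from compound 3 is 3-(trifluoromethyl)phenyl in place of 2-methoxyphenyl on an aromatic carbon. Going by the values given here, the steps that bear on it are the three aryl swaps already measured: a number 3.7 percentage points higher from compound 1 to compound 2 (within the scatter), a number 0.8 percentage points lower from compound 1 to compound 3 (within the scatter) and a number 4.4 percentage points lower from compound 2 to compound 3 (within the scatter), none of them beyond the scatter. On that record a fourth aryl group is expected to give no step beyond the scatter either, so the step of a number 1.7 percentage points higher from compound 3 to compound 4 (within the scatter) is estimated to be small in either direction. Compound 4 is therefore expected to give about 10.5% in this assay, with a range from 0% to 22%.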

Compound 4, a percentage reported as inhibition, at one concentration (the size of the read-out at that concentration, not a potency): 10.1%
Estimate against measurement, compound 4: 0.4 percentage points above, within the range that was stated.
By their numbers in this assay, from the lowest: compounds 3, 1, 4 and 2 (each within the scatter of the next).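

In this assay the swap of 2-methoxyphenyl for 3-(trifluoromethyl)phenyl removes the hydrogen-bond acceptor counted in the leaving group and brings in a larger group, yet the record reads a number 1.3 percentage points higher from compound 3 to compound 4 (within the scatter) and nothing more. The comparisons with the two halogen-bearing aryl groups agree, with a number 3.1 percentage points lower from compound 2 to compound 4 (within the scatter) for the swap from 4-bromophenyl and a number 0.6 percentage points higher from compound 1 to compound 4 (within the scatter) for the swap from 4-fluorophenyl. All four aryl groups at this position therefore stand within the scatter of one another, and the trifluoromethyl group adds no separation among them.

All four compounds carry a substituted phenyl group here, so the compounds shown leave open what an amine, a carboxylic acid or a longer alkyl chain at this position would give. They also leave open whether changes elsewhere on the shared core would move the number.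

No measurement at hand offers an explanation for this flat record.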